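The source may hold more compounds than are shown below. What is called first, only, known or untested is meant among the compounds shown, and "the series" means these compounds.

In an ADME assay on cells (Peritoneal macrophage cell, Mus musculus, strain C57BL/6) for cytotoxicity, read by LDH release (a lower number here means a stronger inhibitor, a higher number a weaker inhibitor), compound 2 `O=C(N/N=C\c1c[nH]c2ccccc12)c1cc[n+]([O-])cc1` gives 30 ug/mL, the higher of the two numbers in hand; compound 1 `CCOC(=O)c1[nH]c2ccccc2c1/C=N\NC(=O)c1ccncc1` gives 16 ug/mL, a gap that lies within the usual scatter of this measurement. Compound 3 `O=C(N/N=C\c1c[nH]c2ccccc12)c1ccncc1` has not yet been measured. It differs from compound 2 at one place: a group of 6 heavy atoms (5 carbon, 1 nitrogen; one six-membered aromatic ring with 1 hetero atom) in place of a group of 7 heavy atoms (5 carbon, 1 nitrogen, 1 oxygen; one six-membered aromatic ring with 1 hetero atom), on a carbonyl carbon. Among the compounds with values here, no measured pair isolates this change, so compound 2 serves as the only anchor. The step from compound 2 to compound 3 is estimated at a 1.4-fold lower number from compound 2 to compound 3 (0.13 log units; within the scatter), not clearly beyond the scatter. Compound 3 is expected to give 22 ug/mL, plausibly between 9 ug/mL and 55 ug/mL.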

Compound 3, half-maximal inhibitory concentration: 40 ug/mL
Compound 3: middle estimate off by 1.8-fold (0.26 log units), on the low side, within the range that was stated.
By their numbers in this assay, from the lowest: compounds 1, 2 and 3 (each within the scatter of the next, the first and the last beyond it).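

In this assay the exchange on the carbonyl carbon, pyridin-4-yl for the group of 7 heavy atoms, amounts to a 1.3-fold higher number from compound 2 to compound 3 (0.12 log units; within the scatter) and so makes no clear difference at this position. Hydrogen in place of ethoxycarbonyl on an aromatic carbon gives a 2.5-fold higher number from compound 1 to compound 3 (0.40 log units; beyond the scatter) as the only step here beyond the scatter, and a modest one. Nothing available accounts for either step. Still open, as far as these compounds go, is whether a carboxylic acid or an amine on that aromatic carbon would move the number as ethoxycarbonyl does.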